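Aryl ether change on the shared core: compound 2 to 3

A few compounds are considered here, and "the series" means these few. Any claim that something is new, unique, unknown or untested is made for them only; others in the source may bear on it.

In a functional assay on A549 cells (Homo sapiens) for antiproliferative activity, read by MTT assay, with a stated time of 72 h (on this read-out higher numbers stand for weaker inhibition and lower numbers for stronger inhibition), compound 2 `NC1=NC2(CCOCC2)N(OCCCOc2cc(Cl)c(Cl)cc2Cl)C(N)=N1` gives 680 nM. Within the data shown here, compound 1 `COc1ccc(OCCCON2C(N)=NC(N)=NC23CCOCC3)cc1` gives 660 nM, and the two values lie within the scatter of each other, so compound 2 holds no distinct place on the numbers so far.

Compound 3 `NC1=NC2(CCOCC2)N(OCCCOc2ccc(Br)cc2)C(N)=N1`, not yet measured, shares the core of compound 2. The change is 4-bromophenyl in place of 2,4,5-trichlorophenyl on an oxygen on a saturated carbon.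

Among the measured compounds shown here, one measured step bears on this place, and it is small: a 1.0-fold higher number from compound 1 to compound 2 (0.01 log units; within the scatter). It exchanges 4-methoxyphenyl for 2,4,5-trichlorophenyl on the same oxygen. For the measured compounds named here, two compounds are thin evidence, and no measured compound yet carries 4-bromophenyl. Going by the values given here, since the only guide is that step within the scatter, no change beyond the scatter is expected in this assay, in either direction. The expected size is a 1.1-fold lower number from compound 2 to compound 3 (0.03 log units; within the scatter). For compound 3 the estimated value is 640 nM, with an expected range of 270 nM to 1500 nM.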

Compound 3, half-maximal inhibitory concentration: 280 nM
For compound 3 the middle estimate is 2.3-fold (0.36 log units) above the measured one; the measured number falls inside the stated range.
By their numbers in this assay, from the lowest: compound 3; then compounds 1 and 2 (each within the scatter of the next).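

In this assay, the aryl group on an oxygen on a saturated carbon proves able to shift the number, which the earlier pair of compounds did not show. The change to 4-bromophenyl gives a 2.4-fold lower number from compound 2 to compound 3 (0.39 log units; beyond the scatter), and bromo in place of methoxy on an aromatic carbon gives a 2.4-fold lower number from compound 1 to compound 3 (0.37 log units; beyond the scatter); both steps are modest. Compounds 1 and 2 remain within the scatter of each other. The two steps therefore describe a single gap separating compound 3 from the other two. Nothing shown here bears on the origin of this gap.

Three compounds cannot tell whether the gap belongs to bromo itself or to the whole 4-bromophenyl group, and a single result does not make a trend, so an unsubstituted phenyl, or an amine or a carboxylic acid on the aromatic ring, would be needed to separate these readings. Also open, on these data alone, is whether the lower number in this assay would persist with a longer chain in place of the present saturated chain on the shared core.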